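Trifluoromethyl for chloro in the benzotriazole-free biaryl series

The compounds below may be only part of what the source reports. "The series", "measured", "known", "first", "only" and "open" are said of these compounds alone.

Series notes. Three measured compounds share one core. Compound 1 `Fc1cc(C(F)(F)F)ccc1-c1ccc(Cn2nnc3ccccc32)cc1` gives 1.2 mL/min/g in an ADME assay on microsomes from liver (Mus musculus, strain NMRI) for metabolic stability, tested at 2.5 uM; a lower number here means slower removal, a higher number faster removal of the compound. Compound 2 `Fc1ccc(-c2ccc(Cn3nnc4ccccc43)cc2)c(Cl)c1` gives 1.5 mL/min/g. Compound 3 `Clc1ccc(-c2ccc(Cn3nnc4ccccc43)cc2)c(Cl)c1` gives 1.3 mL/min/g, which sits within the scatter of both compound 1 and compound 2, so the three numbers are indistinguishable. Within the data shown here, the only step recorded, a 1.2-fold lower number from compound 2 to compound 3 (0.06 log units; within the scatter), is within the scatter. Compound 4 `FC(F)(F)c1ccc(-c2ccc(Cn3nnc4ccccc43)cc2)c(Cl)c1` differs from compound 3 by trifluoromethyl in place of chloro on an aromatic carbon. Among the measured compounds shown here, no measured step involves this exchange; compound 1 already carries a trifluoromethyl group and gives 1.2 mL/min/g, so no movement beyond the scatter is expected. The step from compound 3 to compound 4 is estimated as a 1.1-fold lower number from compound 3 to compound 4 (0.03 log units; within the scatter). Compound 4 is therefore expected at 1.2 mL/min/g, within 0.7 mL/min/g to 2 mL/min/g.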

Compound 4, intrinsic clearance in a liver preparation (reported as CLH), per the amount of preparation that the assay uses: 0.4 mL/min/g
Compound 4: middle estimate off by 3.0-fold (0.48 log units), on the high side; measured number outside the range, below it.
By their numbers in this assay, from the lowest: compound 4; then compounds 1, 3 and 2 (each within the scatter of the next).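

Trifluoromethyl in place of chloro, on the aromatic carbon para to a large group, is the first change in the series to move the number in this assay beyond the scatter, giving a 3.3-fold lower number from compound 3 to compound 4 (0.51 log units; beyond the scatter). The same position gives a 3.8-fold lower number from compound 2 to compound 4 (0.57 log units; beyond the scatter) for trifluoromethyl in place of fluoro. Trifluoromethyl alone does not set the low number, as chloro in place of fluoro gives a 3.0-fold lower number from compound 1 to compound 4 (0.48 log units; beyond the scatter), yet this step cannot be separated from its counterpart on the other core: the same change on two cores in this assay, a 1.2-fold lower number (0.06 log units; within the scatter) from compound 2 to compound 3 and a 3.0-fold lower number (0.48 log units; beyond the scatter) from compound 1 to compound 4, 2.6-fold (0.41 log units) apart, within the scatter of two such steps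

Going by these compounds, whether a nitrile or a methoxy group at this position would give a similar number remains open. So does whether the step would hold with a methyl group in place of the meta chloro group.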